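The compounds below may be only part of what the source reports. "The series", "measured", "known", "first", "only" and "open" are said of these compounds alone.

Measured so far:
- compound 1 `N#Cc1c(N)nc(SCc2ccn[nH]2)c(C#N)c1-c1ccc(OCC2CC2)cc1`: 6%
- compound 2 `N#Cc1c(N)nc(SCC(=O)NO)c(C#N)c1-c1ccc(OCC2CC2)cc1`: 31%

In an assay on CHO cells for displacement of a labelled ligand from adenosine receptor A3 (Homo sapiens), read by scintillation counting, with a stated time of 120 min, tested at 1 uM (a higher number here means more inhibition at the concentration tested (going by the name of the read-out), a lower number less inhibition), compound 1 gives 6%, the lowest of the two numbers; the nearest is compound 2, and the step of a number 25 percentage points higher from compound 1 to compound 2 (beyond the scatter) was brought about by hydroxycarbamoyl in place of 1H-pyrazol-5-yl on a saturated chain carbon bound to a sulfur.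

Compound 3 `CNC(=O)CSc1nc(N)c(C#N)c(-c2ccc(OCC3CC3)cc2)c1C#N` is not yet measured. It differs from compound 1 by methylcarbamoyl in place of 1H-pyrazol-5-yl on a saturated chain carbon bound to a sulfur. Among the measured compounds shown here, the only measured step that bears on it is the one from compound 1 to compound 2, where a carbamoyl-type group replaced the same 1H-pyrazol-5-yl at the same place and the inhibition rose by a number 25 percentage points higher from compound 1 to compound 2 (beyond the scatter). Methylcarbamoyl shares the amide part of hydroxycarbamoyl, so a rise of similar direction is expected in this assay, though nothing shows whether the methyl on the nitrogen matches the hydroxy, so the expected step is taken somewhat smaller with a wide range: a number 14 percentage points higher from compound 1 to compound 3 (beyond the scatter). Compound 3 is therefore estimated at 20%, within 4% to 40%.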

Compound 3, a percentage reported as inhibition, at one concentration (the size of the read-out at that concentration, not a potency): 3%
Beside the measured number, compound 3's estimate is 17 percentage points above it; measured number outside the range, below it.
By their numbers in this assay, from the lowest: compounds 3 and 1 (each within the scatter of the next); then compound 2.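

In this assay, the amide part on a saturated chain carbon bound to a sulfur does not by itself carry the higher reading: a number 3 percentage points lower from compound 1 to compound 3 (within the scatter), so methylcarbamoyl and 1H-pyrazol-5-yl cannot be told apart at this position. The sharper contrast lies on the amide-type nitrogen, where methyl in place of hydroxy gives a number 28 percentage points lower from compound 2 to compound 3 (beyond the scatter), which ties the higher reading of compound 2 to the hydroxy rather than to the carbonyl that compound 2 and compound 3 share. Nothing available here bears on why hydroxy and methyl on that nitrogen read so differently.

From the compounds shown here alone, whether an unsubstituted carboxamide, a carboxylic acid or a methoxy on the amide-type nitrogen would read like compound 2 or like compound 3 remains open, and with it whether the hydroxy itself is required or a wider set of groups would serve. Also open, going by these compounds, is whether the gap between compound 2 and compound 3 at this single concentration would hold as a difference in potency, and whether the hydroxycarbamoyl group would keep its reading with a different aryl group on the shared core.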